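Methylcarbamoyl to carboxy on two cores

The source may hold more compounds than are shown below. What is called first, only, known or untested is meant among the compounds shown, and "the series" means these compounds.

Measured so far in an assay on a protein complex for inhibition of CDK8/Cyclin C (Homo sapiens), with a stated time of 1 h, tested at 10 uM; on this read-out higher numbers stand for more inhibition at the one concentration tested (going by the name of the read-out) and lower numbers for less inhibition:
- compound 1, `CNC(=O)/C=C/c1ccncc1-c1ccc2ccccc2c1`, gives 101%
- compound 2, `O=C(O)/C=C/c1ccncc1-c1ccc2ccccc2c1`, gives 102%
- compound 3, `CNC(=O)/C=C/c1ccncc1-c1ccc2[nH]ccc2c1`, gives 100%

All three numbers sit within the usual scatter of one another, so no order among them is claimed. The difference between the core of compound 1 and the core of compound 3 is not broken down here. Compound 2 arises from compound 1 by hydroxy in place of methylamino on a carbonyl carbon; this gave a number 1 percentage points higher from compound 1 to compound 2 (within the scatter).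

Compound 4, `O=C(O)/C=C/c1ccncc1-c1ccc2[nH]ccc2c1`, is not yet measured. It arises from compound 3 by hydroxy in place of methylamino on a carbonyl carbon, the same change as from compound 1 to compound 2, at a place described in the same words. Among the compounds with values here, only one earlier instance of the change exists, and both of its partners already lie at the top of the read-out, so the prior step carries little information about direction.

Compound 4 is expected to give 100% in this assay, between 90% and 105%, because compound 3 already gives 100% and the earlier step was a number 1 percentage points higher from compound 1 to compound 2 (within the scatter). This estimate means a step of no change at the digits printed from compound 3 to compound 4 (within the scatter), which is expected to stay within the scatter.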

Compound 4, a percentage reported as inhibition, at one concentration (the size of the read-out at that concentration, not a potency): 102%
For compound 4 the middle estimate is 2 percentage points below the measured one; low and high end bracket the measured number.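

In this assay, hydroxy in place of methylamino on a carbonyl carbon gives a number 2 percentage points higher from compound 3 to compound 4 (within the scatter). Set beside the earlier instance, the change reads alike on the two cores: the same change on two cores in this assay, a number 1 percentage points higher (within the scatter) from compound 1 to compound 2 and a number 2 percentage points higher (within the scatter) from compound 3 to compound 4, 1 percentage points apart, within the scatter of two such steps. This shows only that methylcarbamoyl to carboxy carries from one core to the other with no step beyond the scatter; all four numbers lie at the top of the read-out at the one concentration tested, so it does not show that the two groups or the two cores are equal in potency, and a difference hidden at this ceiling cannot be excluded.

Still open, on these data alone, are other groups at this place on the double-bonded chain, such as a primary amide, a nitrile or a longer chain, and whether the change carries to cores beyond these two. Also open, as far as these compounds go, is how the four compounds would order on a potency read-out, which a percentage at one concentration cannot give.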